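Adding sec-butyl to a compound stuck at the limit

The compounds below may be only part of what the source reports. "The series", "measured", "known", "first", "only" and "open" are said of these compounds alone.

Compound 1 (`COC(=O)[C@H](CC(C)C)NC(=O)c1ccc(Oc2nc3ccccc3nc2NC(C)(C)C)cc1`) and compound 2 (`CC(C)(C)Nc1nc2ccccc2nc1Oc1ccc(C(=O)NCC(=O)O)cc1`) share a core and differ only in the group on an amide-type nitrogen. In a functional assay on HeLa cells (Homo sapiens) for antiproliferative activity, read by MTT assay, with a stated time of 48 h (on this read-out higher numbers stand for weaker inhibition and lower numbers for stronger inhibition), compound 1 gives > 50000 nM as a limit of the assay and not a number. In this assay compound 2 gives > 50000 nM as a limit too. Compound 2 therefore offers no number to start from, and it stands with compound 1 at one ceiling (the limit of > 50000 nM in this assay, at which 2 of the 2 values shown sit). Among the measured compounds shown here, the one measured step (a step that the two limits leave unreadable from compound 1 to compound 2) has no size to carry forward.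

Compound 3 (`CC[C@@H](C)[C@H](NC(=O)c1ccc(Oc2nc3ccccc3nc2NC(C)(C)C)cc1)C(=O)O`) turns carboxymethyl into 1-carboxy-2-methylbutyl, with sec-butyl in place of hydrogen on a saturated chain carbon bound to an amide-type nitrogen and a carbonyl carbon. The closest guide is compound 1 with its 1-(methoxycarbonyl)-3-methylbutyl group, whose > 50000 nM is likewise a limit. The expected step (a number no higher from compound 2 to compound 3 (the limit leaves the size open)) is therefore no readable change in this assay in either direction. For compound 3 the estimated value is 50000 nM with an expected range from 20000 nM to 100000 nM as its spread.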

Compound 3, half-maximal inhibitory concentration: 13400 nM
Compound 3: middle estimate off by 3.7-fold (0.57 log units), on the high side, and the stated range ends above it.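

In this assay, sec-butyl on the saturated chain carbon bound to an amide-type nitrogen and a carbonyl carbon produces the only readable number among the compounds shown, with an at least 3.7-fold lower number from compound 2 to compound 3 (0.57 log units; beyond the scatter). This position can therefore move the read-out off the ceiling, and the replacement of 1-(methoxycarbonyl)-3-methylbutyl by 1-carboxy-2-methylbutyl on the amide-type nitrogen points the same way, with an at least 3.7-fold lower number from compound 1 to compound 3 (0.57 log units; beyond the scatter), although that swap alters the chain and the methoxycarbonyl end together, so it cannot be pinned on either one. Both steps give only a smallest size, and their full size stays unknown, since compound 1 and compound 2 share one limit of the assay rather than a number: the limit of > 50000 nM in this assay, at which 2 of the 3 values shown sit.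

On these data alone, it remains open whether a smaller methyl group or a ring-bearing benzyl group on the same carbon would also give a readable number, which would show how much depends on sec-butyl itself. Also open, as far as these compounds go, is whether a methoxycarbonyl group in place of the carboxy end of 1-carboxy-2-methylbutyl would keep the number, which would separate the effect of the chain from that of the end group.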